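The source may report more compounds than this note shows. Statements on the series, on what has been measured and on what is new or still open speak of the compounds shown alone.

On these data alone, compound 1, `O=C(Nc1ccccc1)c1cc(F)ccc1O`, is the starting point of this short series, yet it carries no single number to stand on: in a functional assay on Jurkat cells (Homo sapiens) for cytotoxicity, read by luminescence and CellTiter-Glo, with a stated time of 3 days (a lower number here means a stronger inhibitor, a higher number a weaker inhibitor), compound 1 is recorded as "not determined" (no result reported), so its own strength is unknown. Going by the values given here, the only measured anchor is compound 2, `O=C(Nc1cccc(OC(F)(F)F)c1)c1cc(F)ccc1O`, which shares the same core and adds a trifluoromethoxy group on the amide-side ring; in this assay compound 2 gives 700 nM. Compound 3, `O=C(Nc1ccc([N+](=O)[O-])cc1)c1cc(F)ccc1O`, has not yet been tested. It differs from compound 1 by a single change: nitro in place of hydrogen on an aromatic carbon. Among the compounds with values here, no pair of measured compounds shows what such a change does here, so any expectation rests on the neighbourhood rather than on a recorded step. Since compound 1 has no number, the size of the step from compound 1 to compound 3 in this assay cannot be stated, and no direction beyond the usual scatter can be claimed. Compound 3 is expected to land in the same broad region as compound 2, with an estimated value of 500 nM, most likely between 100 nM and 3000 nM.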

Compound 3, half-maximal inhibitory concentration: 940 nM
Beside the measured number, compound 3's estimate is 1.9-fold (0.27 log units) below it; measured number inside the range.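

Compound 3 cannot be set against compound 1, which carries no single number in this assay and so no new step can be read from this result. No measured evidence bears on the value of compound 3. On these data alone, what putting nitro in place of hydrogen on the core of compound 1 does to strength in this assay stays open.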